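This account rests on a few compounds, and the source may have more. Where it says the series, first, only, none or still open, it means among the compounds named here.

Measured so far:
- compound 1, `c1ccc(COc2ccc(Nc3ncnc4cc5c(cc34)OCCOCCOCCO5)cc2)cc1`: > 100000 nM
- compound 2, `FC(F)(F)c1ccc(COc2ccc(Nc3ncnc4cc5c(cc34)OCCOCCOCCO5)cc2)cc1`: 30700 nM
- compound 3, `FC(F)(F)c1ccc(COc2cccc(Nc3ncnc4cc5c(cc34)OCCOCCOCCO5)c2)cc1`: 24900 nM

In a functional assay on A549 cells (Homo sapiens) for antiproliferative activity, read by MTT assay, with a stated time of 72 h (on this read-out lower numbers stand for stronger inhibition and higher numbers for weaker inhibition), compound 2 gives 30700 nM and compound 3 gives 24900 nM; these two values lie within the scatter of each other. The value of compound 1 is a limit of the assay, not a number (the limit of > 100000 nM in this assay, at which 1 of the 3 values shown sits). Compound 1 arises from compound 2 by hydrogen in place of trifluoromethyl on an aromatic carbon, and this gave an at least 3.2-fold higher number from compound 2 to compound 1 (0.51 log units; beyond the scatter). The difference between the cores of compound 2 and compound 3 is not broken down here.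

Compound 4, `c1ccc(COc2cccc(Nc3ncnc4cc5c(cc34)OCCOCCOCCO5)c2)cc1`, is not yet measured. It arises from compound 3 by hydrogen in place of trifluoromethyl on an aromatic carbon, the same change at the same kind of place. Going by the step from compound 2 to compound 1 an at least 3.2-fold higher number from compound 2 to compound 1 (0.51 log units; beyond the scatter), compound 4 is expected to show a step of a 3.6-fold higher number from compound 3 to compound 4 (0.56 log units; beyond the scatter), a comparable weakening. The estimate for compound 4 is 90000 nM, expected between 45000 nM and 200000 nM, with a real chance that only a limit is reported.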

Compound 4, half-maximal inhibitory concentration: > 100000 nM
Compound 4: a limit, no number; the forecaster's own chance of this, stated with the estimate: 45%; middle value at least 1.1-fold (0.04 log units) from the limit.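

In this assay compound 4 gives > 100000 nM, which is a limit of the assay and not a number. Hydrogen in place of trifluoromethyl gave an at least 4.0-fold higher number from compound 3 to compound 4 (0.60 log units; beyond the scatter), so the change points the same way on both cores shown: the same change on two cores in this assay, an at least 3.2-fold higher number (0.51 log units; beyond the scatter) from compound 2 to compound 1 and an at least 4.0-fold higher number (0.60 log units; beyond the scatter) from compound 3 to compound 4; the limit leaves it open whether they differ This shows that the direction carries over between these two cores, but not how large the true step is on either core, nor whether the two sizes match: the limit of > 100000 nM in this assay, at which 2 of the 4 values shown sit.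

The compounds shown leave open whether a nitrile, a chlorine or a methoxy group at the same place would act as trifluoromethyl does in this assay. They also leave open what an amine or a carboxylic acid there would do.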